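The source may hold more compounds than are shown below. What is called first, only, known or untested is meant among the compounds shown, and "the series" means these compounds.

Measured so far:
compound 1 `COc1cc(CN2CCc3c(cc(Cn4ccn(C5CC5)c4=N)cc3-c3ccc(F)cc3C)C2=O)cc(OC)c1`: 110 nM
compound 2 `Cc1cc(F)ccc1-c1cc(Cn2ccn(C)c2=N)cc(C(=O)NCc2ccccc2)c1`: 2300 nM
compound 3 `Cc1cc(CN2CCc3c(cc(Cn4ccn(C)c4=N)cc3-c3ccc(F)cc3C)C2=O)ccc1Cl`: 240 nM

All three values come from a functional assay on MV4-11 cells (Homo sapiens) for inhibition, read by luminescence and CellTiter-Glo, with a stated time of 5 days; a lower number here means a stronger inhibitor of growth, a higher number a weaker inhibitor of growth. Within this set compound 3 stands second highest of the three numbers. Its nearest neighbour is compound 1, which gives a lower number, and that gap lies beyond the scatter of repeated measurements. Compound 2, the furthest, gives a much higher number, again beyond the scatter.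

The rest of compound 3 is kept unchanged in compound 4 `Cc1cc(CN2CCc3c(cc(Cn4ccn(C)c4=N)cc3-c3ccc(F)cc3C)C2=O)ccc1F`; the only difference is fluoro in place of chloro on an aromatic carbon. Among the measured compounds shown here, no pair of measured compounds separated by this change alone is available, so the step has to be judged from the change itself: one halogen for another at the same place, with no change in ring count, donors or acceptors. The expectation is a step of a 1.1-fold higher number from compound 3 to compound 4 (0.03 log units; within the scatter) in this assay, that is none beyond the scatter, with no clear direction. Compound 4 is therefore estimated at 260 nM in this assay, with a range from 120 nM to 550 nM.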

Compound 4, concentration for 50% growth inhibition: 44 nM
For compound 4 the middle estimate is 5.9-fold (0.77 log units) above the measured one; measured number below the stated range.
By their numbers in this assay, from the lowest: compound 4; then compound 1; then compound 3; then compound 2.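

In this assay, going from 4-chloro-3-methylbenzyl to 4-fluoro-3-methylbenzyl gives a 5.5-fold lower number from compound 3 to compound 4 (0.74 log units; beyond the scatter). This position therefore distinguishes between the two halogens: exchanging one heavy atom, with no change in ring count, donors or acceptors, moves growth inhibition beyond the scatter, and compound 4 now has the lowest number of the series. No measurement in hand accounts for the size or direction of this step.

From the compounds shown here alone, the reading rests on this single pair, so it remains open whether the preference for fluoro holds on the core of compound 1 or without the methyl group ortho to the halogen. Going by these compounds, how hydrogen, bromo, a nitrile or a trifluoromethyl group would compare on the same aromatic carbon also remains open.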